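Pyridin-2-yl to 4-nitrophenyl on the shared core

A few compounds are considered here, and "the series" means these few. Any claim that something is new, unique, unknown or untested is made for them only; others in the source may bear on it.

Measured so far in an ADME assay on Vero cells (Chlorocebus sabaeus) for cytotoxicity, read by MTT assay; a higher number here means a weaker inhibitor, a lower number a stronger inhibitor:
- compound 1 `C=CCOc1cc(OC)c(C(=O)/C=C/c2ccccn2)c(OCC=C)c1` gives 2800 nM
- compound 2 `C=CCOc1cc(OC)c(C(=O)/C=C/c2cc(OC)c(OC)c(OC)c2)c(OCC=C)c1` gives 40900 nM

Compound 1 holds the lower of the two numbers in this assay, and the gap up to compound 2 lies beyond the usual scatter of repeated measurements. Going by the values given here, with only two values, no trend can be claimed for the series.

The next compound to be read is compound 3 `C=CCOc1cc(OC)c(C(=O)/C=C/c2ccc([N+](=O)[O-])cc2)c(OCC=C)c1`. It carries 4-nitrophenyl in place of pyridin-2-yl on a double-bonded chain carbon bound to a double-bonded chain carbon.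

Among the compounds with values here, no measured step between two compounds bears on this change, so the expectation is loose. Within the data shown here, the only guide is the span of the two values, from compound 1 at 2800 nM to compound 2 at 40900 nM. A moderate upward step in this assay is expected, leaving the new number inside that span and nearer its lower end. The expected change is a 2.1-fold higher number from compound 1 to compound 3 (0.33 log units; beyond the scatter). The estimated value for compound 3 is 6000 nM, with an expected range from 1500 nM to 25000 nM.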

Compound 3, half-maximal inhibitory concentration: 12600 nM
Beside the measured number, compound 3's estimate is 2.1-fold (0.32 log units) below it; low and high end bracket the measured number.
By their numbers in this assay, from the lowest: compound 1; then compound 3; then compound 2.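

In this assay, exchanging pyridin-2-yl for 4-nitrophenyl gives a 4.5-fold higher number from compound 1 to compound 3 (0.65 log units; beyond the scatter), the first single-change step available for the series, and it shows that the number responds to this exchange by more than the usual scatter. The change alters two things at once: the ring nitrogen leaves for a ring of carbon only, and a nitro group enters, so this one step cannot divide the shift between them, while compound 3 at 12600 nM still stands under compound 2 at 40900 nM in the printed values. Nothing at hand explains the step or ties it to any property of either group.

Open, on these data alone, is whether an unsubstituted phenyl ring would sit nearer compound 1 or compound 3, which would separate the loss of the ring nitrogen from the gain of the nitro group. Also open, as far as these compounds go, is how an amine or a carboxylic acid in the place of the nitro group would read, and whether pyridin-3-yl or pyridin-4-yl would keep the number of compound 1.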